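Methylation of the ring nitrogen in a cell-growth series

The source may hold more compounds than are shown below. What is called first, only, known or untested is meant among the compounds shown, and "the series" means these compounds.

Measured so far:
compound 1 `Cc1ccc(S(=O)(=O)Nc2cc[nH]c(=O)n2)cc1` — > 100000 nM
compound 2 `Cn1cc(CO)c(N)nc1=O` — > 100000 nM

Both figures above are limits of a functional assay on HeLa cells (Homo sapiens) for inhibition, read by MTT assay, with a stated time of 72 h (a higher number here means a weaker inhibitor, a lower number a stronger inhibitor), not numbers. Compound 1 gives only the limit > 100000 nM there. Compound 2 likewise gives only the limit > 100000 nM. Within the data shown here, compound 1 therefore stands at the limit of > 100000 nM in this assay, at which 2 of the 2 values shown sit, and no measured step between any two compounds exists to set a scale for the series; nothing here tells how far either compound lies beyond the limit.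

Compound 3 `Cc1ccc(S(=O)(=O)Nc2ccn(C)c(=O)n2)cc1` is not yet measured. It differs from compound 1 by methyl in place of hydrogen on an aromatic nitrogen. No measurement here shows what this change does.

With compound 1 at its limit and no direction indicated, the expected step of a number no higher from compound 1 to compound 3 (the limit leaves the size open) is none beyond the scatter, because compound 1 sits at the limit of > 100000 nM in this assay, at which 2 of the 2 values shown sit, and nothing points away from it. For compound 3 the estimate in this assay is 100000 nM, with a range from 30000 nM to 300000 nM, and the most likely outcome is that compound 3 is again reported only as a limit.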

Compound 3, half-maximal inhibitory concentration: > 100000 nM
Compound 3: no number, only a limit; the forecaster's own chance of this, stated with the estimate: 85%; the middle value lies on the limit itself.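

Compound 1 and compound 3 are both reported in this assay only as limits, not numbers, so no step can be read between them for methyl in place of hydrogen on an aromatic nitrogen. The compounds shown leave open how far each lies beyond the limit and whether this change has any effect in this assay.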